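Replacing hydroxymethyl on the shared core

The source may hold more compounds than are shown below. What is called first, only, known or untested is meant among the compounds shown, and "the series" means these compounds.

Compound 1 `CCn1c(=N)sc2cc(OC(F)(F)F)ccc21`: 5 mg/kg
Compound 2 `CCN(CC)C(=O)Cn1c(=N)sc2cc(OC(F)(F)F)ccc21`: 9 mg/kg
Compound 3 `N=c1sc2cc(OC(F)(F)F)ccc2n1CCO`: 8 mg/kg

In a functional assay on the whole organism with Rattus norvegicus as the target (on this read-out lower numbers stand for an effect already at smaller amounts and higher numbers for an effect only at larger amounts of compound), compound 3 gives 8 mg/kg, which lies within the scatter of both other compounds. The change to compound 4 `C[S+]([O-])Cn1c(=N)sc2cc(OC(F)(F)F)ccc21` is a group of 3 heavy atoms (1 carbon, 1 oxygen, 1 sulfur; no ring) in place of a group of 2 heavy atoms (1 carbon, 1 oxygen; no ring), on a saturated chain carbon bound to an aromatic nitrogen. Two measured steps replace a group at this same place: a 1.8-fold higher number from compound 1 to compound 2 (0.26 log units; within the scatter) and a 1.1-fold lower number from compound 2 to compound 3 (0.05 log units; within the scatter). A third, a 1.6-fold higher number from compound 1 to compound 3 (0.20 log units; within the scatter), alters the same chain. Going by the values given here, all three stay within the scatter, so no step beyond the scatter is expected here, although no measured compound carries sulfur in this chain. The expected change is a 1.1-fold lower number from compound 3 to compound 4 (0.06 log units; within the scatter). Compound 4 is estimated at 7 mg/kg, with an expected range from 3 mg/kg to 16 mg/kg.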

Compound 4, dose for half-maximal effect: 2.3 mg/kg
Compound 4: the middle estimate sits 3.0-fold (0.48 log units) above what was measured; measured number outside the range, below it.
By their numbers in this assay, from the lowest: compound 4; then compounds 1, 3 and 2 (each within the scatter of the next).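

In this assay the group that enters on a saturated chain carbon bound to an aromatic nitrogen gives a 3.5-fold lower number from compound 3 to compound 4 (0.54 log units; beyond the scatter) and a 3.9-fold lower number from compound 2 to compound 4 (0.59 log units; beyond the scatter) and also a 2.2-fold lower number from compound 1 to compound 4 (0.34 log units; beyond the scatter) at this place. Going by these compounds alone, the earlier replacements here stayed within the scatter of one another, so this is the first sign that the place responds to what it carries. Nothing given here accounts for this difference. The compounds shown leave open whether the sulfur matters in itself, and how a methylthio group, an amine or a carboxylic acid would read at this place.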